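A Pentyl Chain in Place of 2-Methyl-3-nitrophenyl

A few compounds are considered here, and "the series" means these few. Any claim that something is new, unique, unknown or untested is made for them only; others in the source may bear on it.

In a functional assay on HepG2 cells (Homo sapiens) for antiproliferative activity, read by MTT assay (a lower number here means a stronger inhibitor, a higher number a weaker inhibitor), compound 1 `Cc1c(-n2cc(COc3ccc(/C=C/C(=O)c4cc5c(cc4O)OC(C)(C)CC5)cc3)nn2)cccc1[N+](=O)[O-]` gives 109000 nM. Compound 2 `CC1(C)CCc2c(ccc(C(=O)/C=C/c3ccc(OCc4cn(-c5ccc(Cl)cc5)nn4)cc3)c2O)O1` gives 102000 nM and compound 3 `CC(=O)c1ccc(-n2cc(COc3ccc(/C=C/C(=O)c4ccc5c(c4O)CCC(C)(C)O5)cc3)nn2)cc1` gives 91400 nM, so compound 1 lies within the scatter of both. Compound 4 `CCCCCn1cc(COc2ccc(/C=C/C(=O)c3cc4c(cc3O)OC(C)(C)CC4)cc2)nn1` differs from compound 1 by one change, pentyl in place of 2-methyl-3-nitrophenyl on an aromatic nitrogen. Among the measured compounds shown here, the only measured step, a 1.1-fold lower number from compound 2 to compound 3 (0.05 log units; within the scatter), stays within the scatter, but it swaps acetyl for chloro and never removes the aromatic ring, so it bears on this change only loosely. No step beyond the scatter is therefore expected, and the estimated step is a 1.1-fold lower number from compound 1 to compound 4 (0.06 log units; within the scatter). Compound 4 is expected at 95000 nM, with an estimated range of 40000 nM to 200000 nM.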

Compound 4, half-maximal inhibitory concentration: 95800 nM
Estimate against measurement, compound 4: 1.0-fold (0.00 log units) below; the measured number falls inside the stated range.
By their numbers in this assay, from the lowest: compounds 3, 4, 2 and 1 (each within the scatter of the next).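

At this aromatic nitrogen, in this assay, the step to pentyl is a 1.1-fold lower number from compound 1 to compound 4 (0.06 log units; within the scatter), the first shown that takes the aromatic ring away rather than altering a group on it. Pentyl carries no ring and no hydrogen-bond acceptors, whereas 2-methyl-3-nitrophenyl carries both, yet the two compounds cannot be told apart in this measurement. Nothing available explains this result. On these data alone, it remains open whether a chain ending in an amine or a carboxylic acid, or a longer chain, would move the number beyond the scatter.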